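Fluoro for Chloro on a Shared Triazolopyrimidine Amide

The source may report more compounds than this note shows. Statements on the series, on what has been measured and on what is new or still open speak of the compounds shown alone.

Measured so far:
Compound 1, `CNc1nc(-c2ccccc2)nc2c1nnn2Cc1ccccc1Cl`: 191000000 nM
Compound 2, `CNc1nc(-c2ccccc2)nc2c1nnn2Cc1ccccc1F`: 25000000 nM
Compound 3, `COc1ccc(C(=O)Nc2nc(-c3ccccc3)nc3c2nnn3Cc2ccccc2Cl)cc1`: 20000000 nM

All three were tested in an assay on isolated protein for binding affinity to adenosine receptor A1 (Bos taurus); a higher number here means a weaker inhibitor, a lower number a stronger inhibitor. Compound 1 serves as the starting point. Compound 2 differs from it by a single change, (fluoro in place of chloro on an aromatic carbon), and this change gave a 7.6-fold lower number from compound 1 to compound 2 (0.88 log units; beyond the scatter). Compound 3 differs from compound 1 in another place, ((4-methoxyphenyl)carbonyl in place of methyl on a nitrogen on an aromatic ring), and that change gave a 9.6-fold lower number from compound 1 to compound 3 (0.98 log units; beyond the scatter). Compound 2 and compound 3 lie within the usual scatter of each other in this assay, so no order between them can be read from these numbers.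

Compound 4, `COc1ccc(C(=O)Nc2nc(-c3ccccc3)nc3c2nnn3Cc2ccccc2F)cc1`, has not yet been measured. It carries the change fluoro in place of chloro on an aromatic carbon on the core of compound 3. This is the same change as the one from compound 1 to compound 2, made at the same place; the two cores differ by the change described above, from methyl to (4-methoxyphenyl)carbonyl on the ring nitrogen.

Going by the values given here, with only one earlier example of this change, the expectation rests on it alone: the step from compound 3 to compound 4 in this assay is expected to be about a 7.7-fold lower number from compound 3 to compound 4 (0.89 log units; beyond the scatter), because of the step of a 7.6-fold lower number from compound 1 to compound 2 (0.88 log units; beyond the scatter). On that basis compound 4 is estimated at 2600000 nM, with a likely range from 800000 nM to 8000000 nM.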

Compound 4, inhibition constant: 21900000 nM
Compound 4: middle estimate off by 8.4-fold (0.93 log units), on the low side; the measured number lies above the stated range.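

Fluoro in place of chloro did not give the same result on both cores in this assay, where the step on the core carrying the (4-methoxyphenyl)carbonyl group is a 1.1-fold higher number from compound 3 to compound 4 (0.04 log units; within the scatter), and the two steps differ by more than the scatter allows: the same change on two cores in this assay, a 7.6-fold lower number (0.88 log units; beyond the scatter) from compound 1 to compound 2 and a 1.1-fold higher number (0.04 log units; within the scatter) from compound 3 to compound 4, 8.4-fold (0.92 log units) apart, beyond the scatter of two such steps. Seen from the other side, (4-methoxyphenyl)carbonyl in place of methyl on the core with the fluoro group gives a 1.1-fold lower number from compound 2 to compound 4 (0.06 log units; within the scatter), so this change also depends on the core that receives it: the same change on two cores in this assay, a 9.6-fold lower number (0.98 log units; beyond the scatter) from compound 1 to compound 3 and a 1.1-fold lower number (0.06 log units; within the scatter) from compound 2 to compound 4, 8.4-fold (0.92 log units) apart, beyond the scatter of two such steps. These four compounds show that the two changes do not simply add up in this series, so a step measured on one core did not carry over to the other, but they do not show why, and a single pair of cores cannot say how either change would behave on a further core.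

Going by these compounds, it remains open whether the same dependence would appear with bromo, methyl or methoxy in the place of the chloro. On these data alone, it is equally open whether a smaller group on the ring nitrogen, such as acetyl, would behave like (4-methoxyphenyl)carbonyl.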